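Hydrazone series on a shared core: hydroxy removal

This account rests on a few compounds, and the source may have more. Where it says the series, first, only, none or still open, it means among the compounds named here.

Measured so far in a functional assay on HCT-116 cells (Homo sapiens) for antiproliferative activity, read by MTT assay; on this read-out higher numbers stand for weaker inhibition and lower numbers for stronger inhibition:
Compound 1, `Cn1c(=O)c(=O)n(C2CCCC2)c2nc(N/N=C/c3ccccc3)ncc21`, sits at the limit of > 100000 nM, a limit and not a number.
Compound 2, `Cn1c(=O)c(=O)n(C2CCCC2)c2nc(N/N=C/c3ccc(O)cc3)ncc21`, gives 72500 nM.
Compound 3, `Cn1c(=O)c(=O)n(C2CCCC2)c2nc(N/N=C/c3cc(C(F)(F)F)c(O)c(C(F)(F)F)c3)ncc21`, gives 27100 nM.

Compound 3 holds the lowest of the two numbers, with compound 2 the nearest, beyond the usual scatter. The difference between the cores of compound 3 and compound 2 is not broken down here.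

One change is seen twice among these compounds. From compound 2 to compound 1 it is hydrogen in place of hydroxy on an aromatic carbon. The step it made is an at least 1.3-fold higher number from compound 2 to compound 1 (0.13 log units; that floor lies within the scatter), a floor that rests on (the limit of > 100000 nM in this assay, at which 1 of the 3 values shown sits), so its true size is not known. The same kind of change leads from compound 3 to the still unmeasured compound 4, `Cn1c(=O)c(=O)n(C2CCCC2)c2nc(N/N=C/c3cc(C(F)(F)F)cc(C(F)(F)F)c3)ncc21`: hydrogen in place of hydroxy on an aromatic carbon. The surroundings are not identical: around the place in compound 3 the carbon is ortho to two trifluoromethyl groups (4 heavy atoms each), while in compound 2 it is only para to a large group.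

For compound 4 the step from compound 3 is expected to run in the same direction as the measured one, a 2.4-fold higher number from compound 3 to compound 4 (0.38 log units; beyond the scatter). This expectation rests on the measured step after the same change, an at least 1.3-fold higher number from compound 2 to compound 1 (0.13 log units; that floor lies within the scatter). Compound 4 is thus estimated at 65000 nM in this assay, within 25000 nM to 150000 nM, with a real chance that only a limit is returned.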

Compound 4, half-maximal inhibitory concentration: 4360 nM
Compound 4: middle estimate off by 15-fold (1.17 log units), on the high side, and the stated range ends above it.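

In this assay, hydrogen in place of hydroxy, on the aromatic carbon ortho to two trifluoromethyl groups, gives a 6.2-fold lower number from compound 3 to compound 4 (0.79 log units; beyond the scatter). The change therefore does not carry over from one core to the other in this series, not even in direction: the same change on two cores in this assay, an at least 1.3-fold higher number (0.13 log units; that floor lies within the scatter) from compound 2 to compound 1 and a 6.2-fold lower number (0.79 log units; beyond the scatter) from compound 3 to compound 4, at least 8.5-fold (0.93 log units) apart, beyond the scatter of two such steps

What this does not show is the true size of the earlier step, or any rule for further cores, since compound 1 stands at a limit and not a number and only two pairs are available: the limit of > 100000 nM in this assay, at which 1 of the 4 values shown sits.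

Neither pair says what separates the two outcomes, so the series leaves open whether the trifluoromethyl groups are what goes with the reversal, a question that a single trifluoromethyl group or chlorine atoms in their place on the same ring could address. Also open, going by these compounds, is how other groups on the carbon that carries the hydroxy in compound 3 would read in this assay, for example a methoxy group, an amine or a carboxylic acid.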